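The source may report more compounds than this note shows. Statements on the series, on what has been measured and on what is new or still open speak of the compounds shown alone.

Measured so far in a functional assay on the whole organism for inhibition, with Rattus norvegicus as the target, read by paw edema; a higher number here means that more compound is needed for the effect, a lower number that less compound is needed:
- Compound 1 `O=C(O)c1cc(-c2cc[nH]n2)ccc1O`: > 250 mg/kg
- Compound 2 `O=C(O)c1cc(-c2cscn2)ccc1O`: 95 mg/kg

The entry for compound 1, > 250 mg/kg, is a limit of the assay and not a number. For the measured compounds named here, compound 2 therefore holds the only true number, 95 mg/kg. Compound 3 `O=C(O)c1cc(-n2ccnn2)ccc1O` changes one group of compound 2: 1H-1,2,3-triazol-1-yl in place of 1,3-thiazol-4-yl on an aromatic carbon. Going by the values given here, the one measured step that bears on this is an at least 2.6-fold lower number from compound 1 to compound 2 (0.42 log units; beyond the scatter), so exchanging this group can shift the result in this assay. The entering 1H-1,2,3-triazol-1-yl has no sulfur, like the 1H-pyrazol-3-yl of compound 1, so a modest rise is expected, a 1.6-fold higher number from compound 2 to compound 3 (0.20 log units; within the scatter). For compound 3 the estimated dose is 150 mg/kg, with an expected range of 70 mg/kg to 320 mg/kg.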

Compound 3, dose for half-maximal effect: 150 mg/kg
Compound 3: the middle estimate sits on the measured number at the digits printed; low and high end bracket the measured number.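

Exchanging 1,3-thiazol-4-yl for 1H-1,2,3-triazol-1-yl on this carbon, para to a hydroxy group, gives a 1.6-fold higher number from compound 2 to compound 3 (0.20 log units; within the scatter) in this assay, so a ring without sulfur can sit here with no change beyond the scatter, which compound 1 alone could not show. The other new comparison reads an at least 1.6-fold lower number from compound 1 to compound 3 (0.22 log units; that floor lies within the scatter), so no real separation from the 1H-pyrazol-3-yl ring can be claimed. The entry for compound 1 is a limit of the assay, not a number: the limit of > 250 mg/kg in this assay, at which 1 of the 3 values shown sits.

Still open, from the compounds shown here alone, is how this position responds to groups of another kind, such as a simple amine or an unfused phenyl ring.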